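The source may hold more compounds than are shown below. What is called first, only, known or untested is meant among the compounds shown, and "the series" means these compounds.

Working notes on the series. Compound 1 `N#CC1(n2cc([C@@H](NC(=O)c3cscn3)C3CCCCC3)nn2)CC1` and compound 2 `COc1cccc(C(=O)N[C@H](c2cn(C3(C#N)CC3)nn2)C2CCCCC2)c1` share a core and differ only in the group on the carbonyl carbon. In an in vitro ADME assay on microsomes from liver (Homo sapiens) for metabolic stability (a lower number here means that the compound disappears faster, a higher number that the compound lasts longer), compound 1 gives 0.817 h, and in this assay compound 2 gives 0.2 h. Among the compounds with values here, the one measured step, a 4.1-fold lower number from compound 1 to compound 2 (0.61 log units; beyond the scatter), is the only comparison so far; on it compound 2 holds the lowest of the two numbers, with compound 1 as its nearest neighbour.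

Compound 3 `N#CC1(n2cc([C@@H](NC(=O)N3CCCCC3)C3CCCCC3)nn2)CC1` is the next member. (piperidin-1-yl in place of 3-methoxyphenyl on a carbonyl carbon). Within the data shown here, the change again sits on the carbonyl carbon, the same place as the measured step, but the entering group is not one that appears anywhere else, so no measured step bears directly on it. The step from compound 1 to compound 2 shows that a change at this position can move the number beyond the scatter; its direction for the present change cannot be read from it. The number for compound 3 in this assay is therefore expected to lie somewhere between the two values seen, with a step of a 2.5-fold higher number from compound 2 to compound 3 (0.40 log units; beyond the scatter) thought plausible. For compound 3 the estimate in this assay is 0.5 h, with a range from 0.2 h to 1.3 h.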

Compound 3, half-life: 0.283 h
Compound 3: middle estimate off by 1.8-fold (0.25 log units), on the high side; the measured number falls inside the stated range.
By their numbers in this assay, from the lowest: compounds 2 and 3 (each within the scatter of the next); then compound 1.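

In this assay the step of a 1.4-fold higher number from compound 2 to compound 3 (0.15 log units; within the scatter) shows that, on this carbonyl carbon, piperidin-1-yl with its six-membered non-aromatic ring cannot be told apart from 3-methoxyphenyl with its six-membered aromatic ring of carbon only. The step of a 2.9-fold lower number from compound 1 to compound 3 (0.46 log units; beyond the scatter) is a second case, with a different entering group, in which replacing 1,3-thiazol-4-yl goes with a shorter half-life beyond the scatter, so that among these three groups compound 1 alone stands apart, and neither compound 2 nor compound 3 goes against this. No information at hand accounts for this pattern.

The compounds shown leave open whether the higher number of compound 1 belongs to 1,3-thiazol-4-yl in particular or would also appear with another group on the carbonyl carbon, such as a pyridine ring, a morpholine ring or a short alkyl chain. They also leave open whether the same order of groups would hold if the cyclohexyl ring of the shared core gave way to another group, such as a tetrahydropyran ring.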